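Swapping a Hydroxycyclohexyl Amide for a Morpholine Amide

This account rests on a few compounds, and the source may have more. Where it says the series, first, only, none or still open, it means among the compounds named here.

Of the compounds shown here, three built on one shared core have been tested in an ADME assay on MRC5 cells (Homo sapiens) for inhibition, with a stated time of 72 h; on this read-out lower numbers stand for an effect already at smaller amounts and higher numbers for an effect only at larger amounts of compound. Compound 1 `CO[C@H]1CC[C@H](NC(=O)c2n[nH]cc2NC(=O)c2cnc3ccccn23)CC1` gives 5900 nM, compound 3 `CO[C@H]1CC[C@H](NC(=O)c2n[nH]cc2NC(=O)c2ccc(-c3ccccc3)o2)CC1` gives 100 nM, and compound 2 `COc1cccc(OC)c1C(=O)Nc1c[nH]nc1C(=O)N[C@H]1CC[C@H](O)CC1` gives 34000 nM. Compound 2 therefore stands at the top of the three numbers in this assay: compound 1 and compound 3 both lie below it by more than the usual scatter, with compound 3 the furthest away.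

Compound 4 `COc1cccc(OC)c1C(=O)Nc1c[nH]nc1C(=O)NN1CCOCC1` has not yet been measured. It differs from compound 2 in one place: morpholin-4-yl in place of 4-hydroxycyclohexyl on an amide-type nitrogen. Among the compounds with values here, no pair of measured compounds shows this same change, so there is no measured step to lean on. The rest of the molecule stays as it is, and compound 2 already sits at the high end of the range seen. The expectation is that compound 4 will give a number close to that of compound 2, with the step of a 1.2-fold higher number from compound 2 to compound 4 (0.07 log units; within the scatter) expected to be small, if anything slightly upward. Compound 4 is thus estimated at 40000 nM, expected to fall between 10000 nM and 120000 nM.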

Compound 4, half-maximal effective concentration: > 50000 nM
Compound 4 was reported as a limit; the forecaster's own chance of this, stated with the estimate: 35%; middle value at least 1.2-fold (0.09 log units) from the limit.
By their numbers in this assay, from the lowest: compound 3; then compound 1; then compound 2. At a limit, above all of these: compound 4.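

In this assay compound 4 is reported as > 50000 nM, which is a limit of the assay and not a number. Morpholin-4-yl in place of 4-hydroxycyclohexyl on an amide-type nitrogen is the only change at this position with a measured outcome, and it gives an at least 1.4-fold higher number from compound 2 to compound 4 (0.16 log units; that floor lies within the scatter); that floor does not separate the two compounds, but the swap brings no move toward a lower number. The true size of the step stays unknown because compound 4 carries a limit: the limit of > 50000 nM in this assay, at which 1 of the 4 values shown sits.

The compounds shown leave open how other groups on this amide-type nitrogen would read, such as a 2-aminoethyl chain with its amine or a carboxymethyl group with its carboxylic acid. Also open, going by these compounds, is whether morpholin-4-yl would read the same way on compound 3.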